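One Fluorine Shift, Tested on Two Related Cores

The source may hold more compounds than are shown below. What is called first, only, known or untested is meant among the compounds shown, and "the series" means these compounds.

Measured compounds:
Compound 1, `O=c1[nH]cc(S(=O)(=O)Nc2ccccc2-c2cn(-c3ccccc3F)nn2)c(=O)[nH]1`: 7370 nM
Compound 2, `O=c1[nH]cc(S(=O)(=O)Nc2ccccc2-c2cn(-c3cccc(F)c3)nn2)c(=O)[nH]1`: 8130 nM
Compound 3, `O=c1[nH]cc(S(=O)(=O)Nc2ccc(-c3cn(-c4ccccc4F)nn3)cc2)c(=O)[nH]1`: 5960 nM

All three were tested in a functional assay on A549 cells (Homo sapiens) for antiproliferative activity, read by MTT assay, with a stated time of 24 h; on this read-out higher numbers stand for weaker inhibition and lower numbers for stronger inhibition. Compound 1 and compound 2 share a core and differ only in one way: 3-fluorophenyl in place of 2-fluorophenyl on an aromatic nitrogen. This change gave a 1.1-fold higher number from compound 1 to compound 2 (0.04 log units; within the scatter), so the two numbers cannot be told apart. Compound 3 carries a different core; how its core differs from that of compound 1 is not broken down here, but in this assay compound 3 gives 5960 nM, within the scatter of both compound 1 and compound 2.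

Compound 4, `O=c1[nH]cc(S(=O)(=O)Nc2ccc(-c3cn(-c4cccc(F)c4)nn3)cc2)c(=O)[nH]1`, has not been measured. It stands to compound 3 as compound 2 stands to compound 1: 3-fluorophenyl in place of 2-fluorophenyl on an aromatic nitrogen. The surroundings of the change read the same word for word in both pairs, so it is the same change on a second core.

The step from compound 3 to compound 4 in this assay is expected to be a 1.1-fold higher number from compound 3 to compound 4 (0.04 log units; within the scatter), because a 1.1-fold higher number from compound 1 to compound 2 (0.04 log units; within the scatter) showed that this change barely moved the number on the first core. The estimate for compound 4 is therefore 6500 nM, with a likely range from 3500 nM to 12000 nM.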

Compound 4, half-maximal inhibitory concentration: 9980 nM
For compound 4 the middle estimate is 1.5-fold (0.19 log units) below the measured one; the range from low to high includes it.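

Moving the fluorine from 2-fluorophenyl to 3-fluorophenyl on the second core, tested in this assay, gave a 1.7-fold higher number from compound 3 to compound 4 (0.22 log units; within the scatter), so on this core too the step stays inside the usual noise of the measurement. Set side by side, the two steps differ by no more than repeat measurements would: the same change on two cores in this assay, a 1.1-fold higher number (0.04 log units; within the scatter) from compound 1 to compound 2 and a 1.7-fold higher number (0.22 log units; within the scatter) from compound 3 to compound 4, 1.5-fold (0.18 log units) apart, within the scatter of two such steps. On these two cores, then, the change carried over without a detectable difference, but since both steps lie within the scatter, this does not show that the change has a real effect on either core, nor how it would behave on any other core.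

On these data alone, the group on the aromatic nitrogen appears here only as 2-fluorophenyl or 3-fluorophenyl, so it remains open whether a plain phenyl, a chlorophenyl or a phenyl bearing a carboxylic acid would move the number beyond the scatter. As far as these compounds go, it also remains open whether a group of that kind would give the same step on both cores.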